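Adding a Methyl to the Hydrazone: Growth Inhibition Expected Unchanged

The source may report more compounds than this note shows. Statements on the series, on what has been measured and on what is new or still open speak of the compounds shown alone.

Three compounds have been measured in a functional assay on HT-29 cells (Homo sapiens) for cytotoxicity, read by sulforhodamine B assay; a lower number here means a stronger inhibitor of growth, a higher number a weaker inhibitor of growth:

Compound 1, `CC1=CC[C@@H]([C@@](C)(O)CCCC(C)(C)NC=S)CC1`: 11400 nM
Compound 2, `CC1=CC[C@@H]([C@@](C)(O)CCCC(C)(C)NC(=S)N/N=C\c2ccccc2)CC1`: 9960 nM
Compound 3, `CC1=CC[C@@H]([C@@](C)(O)CCCC(C)(C)NC(=S)N/N=C\c2cccc(Cl)c2)CC1`: 6890 nM

Compound 2 has the second highest of the three numbers. Its nearest neighbour is compound 1, the step being a 1.1-fold lower number from compound 1 to compound 2 (0.06 log units; within the scatter); its furthest is compound 3, with a 1.4-fold lower number from compound 2 to compound 3 (0.16 log units; within the scatter). Both steps lie within the scatter, so on these numbers the three compounds cannot be told apart.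

Compound 4, `CC1=CC[C@@H]([C@@](C)(O)CCCC(C)(C)NC(=S)N/N=C(/C)c2ccccc2)CC1`, differs from compound 2 in one place: a group of 9 heavy atoms (8 carbon, 1 nitrogen; one six-membered aromatic ring of carbon only) in place of a group of 8 heavy atoms (7 carbon, 1 nitrogen; one six-membered aromatic ring of carbon only), on an amide-type nitrogen. In plain terms, a methyl replaces the hydrogen on the carbon of the hydrazone double bond.

The two measured steps both touched this same outer part of the molecule, and neither moved the number beyond the scatter. Nothing in the data points to a larger effect from a single added carbon there. Compound 4 is therefore expected to give about 9000 nM in this assay, with a range from 4000 nM to 20000 nM, meaning an expected step of a 1.1-fold lower number from compound 2 to compound 4 (0.04 log units; within the scatter), which is no change beyond the scatter.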

Compound 4, concentration for 50% growth inhibition: 28400 nM
Beside the measured number, compound 4's estimate is 3.2-fold (0.50 log units) below it, and the stated range ends below it.
By their numbers in this assay, from the lowest: compounds 3, 2 and 1 (each within the scatter of the next); then compound 4.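

Among the compounds shown here, the carbon of the hydrazone double bond is sensitive to small changes in this assay: a methyl in place of its hydrogen gives a 2.9-fold higher number from compound 2 to compound 4 (0.46 log units; beyond the scatter) and so produces the first step here that lies beyond the scatter. The swap linking the chloro compound to the methyl compound is larger still, with a 4.1-fold higher number from compound 3 to compound 4 (0.62 log units; beyond the scatter) also beyond the scatter. For the compounds shown here, the outer part of the molecule therefore matters more than the earlier steps suggested, since neither adding the group of compound 2 nor adding the chloro moved the number beyond the scatter.

Nothing available here explains why this one carbon weakens growth inhibition. Going by these compounds, it remains open whether an ethyl, a longer chain or an amine on that same carbon would weaken it further, or leave it unchanged.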